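Swapping a fused bicyclic amide for a cinnamoyl group

The source may hold more compounds than are shown below. What is called first, only, known or untested is meant among the compounds shown, and "the series" means these compounds.

Three amides built on one shared core have been tested in a functional assay on A2780 cells (Homo sapiens) for cytotoxicity, read by MTT assay, with a stated time of 72 h; on this read-out higher numbers stand for weaker inhibition and lower numbers for stronger inhibition. Compound 1 `CN1[C@@H]2c3[nH]c4ccccc4c3C[C@H]1[C@H](C#N)N1[C@@H](CNC(=O)c3ccc(Cl)cc3)c3[nH]c4ccccc4c3C[C@@H]21` gives 230 nM. Compound 2 `CN1[C@@H]2c3[nH]c4ccccc4c3C[C@H]1[C@H](C#N)N1[C@@H](CNC(=O)c3cccc4c3CCCC4)c3[nH]c4ccccc4c3C[C@@H]21` gives 810 nM, the highest of the three numbers, and compound 3 `CN1[C@@H]2c3[nH]c4ccccc4c3C[C@H]1[C@H](C#N)N1[C@@H](CNC(=O)c3cc4ccccc4s3)c3[nH]c4ccccc4c3C[C@@H]21` gives 20 nM, the lowest. The measured steps show the amide substituent matters a great deal: a 3.5-fold higher number from compound 1 to compound 2 (0.55 log units; beyond the scatter), whereas a 12-fold lower number from compound 1 to compound 3 (1.06 log units; beyond the scatter) and a 41-fold lower number from compound 2 to compound 3 (1.61 log units; beyond the scatter).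

Compound 4 `CN1[C@@H]2c3[nH]c4ccccc4c3C[C@H]1[C@H](C#N)N1[C@@H](CNC(=O)/C=C/c3ccccc3)c3[nH]c4ccccc4c3C[C@@H]21` is not yet measured. It differs from compound 2 by one change, (2-phenylethenyl in place of 1,2,3,4-tetrahydronaphthalen-5-yl on a carbonyl carbon). The step from compound 2 to compound 3 shows how strongly this part of the molecule can move the number, and the step from compound 2 to compound 1 shows that leaving the tetrahydronaphthalenyl group already lowers it. Among the measured compounds shown here, the phenylethenyl group, like the benzothiophenyl group, is fully unsaturated and flat, so a move in the same direction is expected, though smaller, since only two of three steps point that way and none involves this exact group. Compound 4 is expected to give 150 nM, estimated between 40 nM and 600 nM. This means an expected step of a 5.4-fold lower number from compound 2 to compound 4 (0.73 log units; beyond the scatter).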

Compound 4, half-maximal inhibitory concentration: 770 nM
The estimate for compound 4 lay 5.1-fold (0.71 log units) below the measured number, and the stated range ends below it.
By their numbers in this assay, from the lowest: compound 3; then compound 1; then compounds 4 and 2 (each within the scatter of the next).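

Replacing the 1,2,3,4-tetrahydronaphthalen-5-yl group with 2-phenylethenyl makes no change beyond the scatter (a 1.1-fold lower number from compound 2 to compound 4 (0.02 log units; within the scatter)), so giving up the non-aromatic ring and adding a double bond outside the aromatic ring does not by itself lower the number. The low number of compound 3 therefore does not carry over to this flat-drawn open-chain group (a 39-fold higher number from compound 3 to compound 4 (1.59 log units; beyond the scatter)), and 2-phenylethenyl also falls short of 4-chlorophenyl (a 3.3-fold higher number from compound 1 to compound 4 (0.52 log units; beyond the scatter)). No measurement is available to explain why these amide groups separate as they do.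

The compounds shown leave open whether a saturated 2-phenylethyl group would give a number different from that of compound 4. They also leave open whether thiophen-2-yl or 1-benzofuran-2-yl would keep a number close to that of compound 3 (20 nM).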